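Replacing the sulfonyl aryl group of compound 1

The compounds below may be only part of what the source reports. "The series", "measured", "known", "first", "only" and "open" are said of these compounds alone.

compound 1 `COc1ccc(S(=O)(=O)/C(=C/c2ccc(Br)cc2)C(=O)c2ccc(Br)cc2)cc1` — 6000 nM
compound 2 `COc1ccc(S(=O)(=O)/C(=C/c2ccc(Cl)cc2Cl)C(=O)c2ccc(Br)cc2)cc1` — 20000 nM
compound 3 `CN(C)c1ccc(/C=C(/SCc2ccc(Cl)cc2)C(=O)c2ccc([N+](=O)[O-])cc2)cc1` — > 100000 nM (a limit)

In a functional assay on DU-145 cells (Homo sapiens) for inhibition, read by trypan blue exclusion, with a stated time of 96 h (a higher number here means a weaker inhibitor of growth, a lower number a stronger inhibitor of growth), compound 1 gives 6000 nM, the lowest of the two numbers reported. Compound 2 gives 20000 nM in this assay. For compound 3 this assay reports only a limit, > 100000 nM, (the limit of > 100000 nM in this assay, at which 1 of the 3 values shown sits). Going by the values given here, the single measured step, a 3.3-fold higher number from compound 1 to compound 2 (0.52 log units; beyond the scatter), changes the aryl group on the double-bonded chain carbon, not the group on the sulfonyl sulfur.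

Compound 4 `O=C(/C(=C\c1ccc(Br)cc1)S(=O)(=O)c1ccccc1Br)c1ccc(Br)cc1` differs from compound 1 by 2-bromophenyl in place of 4-methoxyphenyl on a sulfonyl sulfur. Among the compounds with values here, no measured step touches the sulfonyl aryl group, so for compound 4 in this assay no step beyond the scatter is expected, with the weaker side slightly favoured. Compound 4 is therefore estimated at 9000 nM, between 3000 nM and 30000 nM. This estimate means a 1.5-fold higher number from compound 1 to compound 4 (0.18 log units; within the scatter).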

Compound 4, concentration for 50% growth inhibition: 1000 nM
Compound 4: the middle estimate sits 9.0-fold (0.95 log units) above what was measured; measured number outside the range, below it.
By their numbers in this assay, from the lowest: compound 4; then compound 1; then compound 2. At a limit, above all of these: compound 3.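

In this assay, 2-bromophenyl in place of 4-methoxyphenyl on the sulfonyl sulfur gives a 6.0-fold lower number from compound 1 to compound 4 (0.78 log units; beyond the scatter). This shows that the group at this position, which the earlier step left unchanged, can also shift growth inhibition beyond the scatter. Nothing available gives a measured reason for this step.

The compounds shown leave open whether the bromine itself or its place on the ring carries the step. They also leave open how a 2-chlorophenyl, a 4-bromophenyl or an aminophenyl group on the sulfonyl sulfur would read.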